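Series notes: amide substituent at the carbonyl carbon

The source may report more compounds than this note shows. Statements on the series, on what has been measured and on what is new or still open speak of the compounds shown alone.

The shared core carries a 4-(4-chlorophenyl)piperidine amide of valine, and the variable part sits on the carbonyl carbon of the second amide. In an assay on THP-1 cells for displacement of a labelled ligand from C-C chemokine receptor type 1 (Homo sapiens) (a higher number here means a weaker inhibitor, a lower number a stronger inhibitor), compound 1 `CC(C)C(=O)NC(C(=O)N1CCC(c2ccc(Cl)cc2)CC1)C(C)C` gives 388 nM, compound 2 `Cc1ccccc1C(=O)NC(C(=O)N1CCC(c2ccc(Cl)cc2)CC1)C(C)C` gives 36 nM, and compound 3 `Cc1ccccc1C(=O)N[C@@H](C(=O)N1CCC(c2ccc(Cl)cc2)CC1)C(C)C` gives 32 nM. Compound 3 stands lowest of the three numbers, but its gap to compound 2 is within the scatter, while compound 1 is well separated an 11-fold lower number from compound 1 to compound 2 (1.03 log units; beyond the scatter). Compound 3 differs from compound 2 only in the drawing of a stereocentre, a 1.1-fold lower number from compound 2 to compound 3 (0.05 log units; within the scatter), consistent with the fact that one of compounds 2 and 3 is drawn with a defined configuration and the other without, at the place where they differ.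

The next compound, compound 4 `CC(C)[C@@H](NC(=O)c1ccc(F)c(F)c1)C(=O)N1CCC(c2ccc(Cl)cc2)CC1`, changes the aryl group: 3,4-difluorophenyl in place of 2-methylphenyl on a carbonyl carbon. For the measured compounds named here, the only measured step at this position, the change from isopropyl to 2-methylphenyl, an 11-fold lower number from compound 1 to compound 2 (1.03 log units; beyond the scatter), shows that an aromatic ring on this carbonyl carbon is favoured over the branched alkyl, but no measured pair compares one substituted phenyl with another, so the effect of exchanging 2-methylphenyl for 3,4-difluorophenyl is not anchored. As the aromatic ring is retained, the expectation for compound 4 in this assay is a step of a 1.6-fold higher number from compound 3 to compound 4 (0.19 log units; within the scatter), which is within the scatter. Compound 4 is thus estimated at 50 nM, with a range from 15 nM to 200 nM.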

Compound 4, half-maximal inhibitory concentration: 14 nM
Compound 4: middle estimate off by 3.6-fold (0.55 log units), on the high side; measured number outside the range, below it.
By their numbers in this assay, from the lowest: compound 4; then compounds 3 and 2 (each within the scatter of the next); then compound 1.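

In this assay, for the compounds shown here, the exchange of the aryl group gives a 2.3-fold lower number from compound 3 to compound 4 (0.36 log units; beyond the scatter), the first measured comparison of one substituted phenyl with another on this carbonyl carbon. With the aromatic ring kept, the choice of ring substituents therefore still moves the number beyond the scatter, so the gain at this position does not end with the change from the branched alkyl to an aromatic ring, although this step is modest beside an 11-fold lower number from compound 1 to compound 2 (1.03 log units; beyond the scatter). Nothing at hand bears on the origin of the new step.

The exchange of 2-methylphenyl for 3,4-difluorophenyl alters the ring substituents in a single move, so the compounds shown leave open what each substituent contributes, a question that unsubstituted phenyl, 3-fluorophenyl or 4-fluorophenyl on the same carbonyl carbon would address. Also open is how far this position tolerates groups of a different kind, such as a pyridine ring, a carboxylic acid or a longer chain ending in an amine, since every aromatic group shown here is a substituted phenyl.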